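A few compounds are considered here, and "the series" means these few. Any claim that something is new, unique, unknown or untested is made for them only; others in the source may bear on it.

The study covers three measured compounds and a fourth whose number is awaited. Compound 1 `CS(=O)(=O)Cc1cc([C@]23CCOC[C@H]2C3)nc(-c2cccc(O)c2)n1` carries a (methylsulfonyl)methyl group on the shared core. Compound 2 `CS(=O)(=O)Cc1cc(C2=CCOCC2)nc(-c2cccc(O)c2)n1` differs from it in one place, and compound 3 `CCNC(=O)Nc1ccc(-c2nccc(C3=CCOCC3)n2)cc1` has a different core and a different aryl group. In a physicochemical assay for lipophilicity (a higher number here means a more lipophilic compound, a lower number a more polar compound), compound 1 gives 3.7. In this assay compound 3 gives 3.6, which is within the scatter of compound 1, so no order between these two can be read. Compound 2 gives 3.3, and the step of a number 0.40 log units lower from compound 1 to compound 2 (beyond the scatter) is the only one beyond the scatter among the three.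

Compound 4 `CC(C)(c1cc([C@]23CCOC[C@H]2C3)nc(-c2cccc(O)c2)n1)S(C)(=O)=O` is the next step from compound 1: 1-methyl-1-(methylsulfonyl)ethyl in place of (methylsulfonyl)methyl on an aromatic carbon. For the measured compounds named here, none of the measured steps bears on this change: the step from compound 1 to compound 2 concerns the ring system, not the sulfonyl-bearing group, and compound 3, with its different core and aryl group, has no single-point comparison to compound 1, so its value stands alone. Going by the values given here, with no measured step to lean on, the estimate rests on the change alone, and a modest rise is expected, a number 0.60 log units higher from compound 1 to compound 4 (beyond the scatter). Compound 4 is therefore estimated at 4.3, with a range from 3.8 to 4.8.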

Compound 4, partition coefficient: 4.8
Beside the measured number, compound 4's estimate is 0.50 log units below it; low and high end bracket the measured number.
By their numbers in this assay, from the lowest: compounds 2, 3 and 1 (each within the scatter of the next, the first and the last beyond it); then compound 4.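

In this assay, 1-methyl-1-(methylsulfonyl)ethyl in place of (methylsulfonyl)methyl on an aromatic carbon gives a number 1.10 log units higher from compound 1 to compound 4 (beyond the scatter), a large step and the first measured one at this position. Thus the group at this position can shift the number, and the step is larger than the modest ring-system step, a number 0.40 log units lower from compound 1 to compound 2 (beyond the scatter). The two groups match in their counted hydrogen-bond donors and acceptors, neither has a ring or a net charge, and the entering group differs only by added carbon, but no measurement here explains the size of the step.

What the compounds shown leave open is how this single step would change with other groups at this position, such as 1-(methylsulfonyl)ethyl, 1-(methylsulfonyl)cyclopropyl or an amine in place of the sulfonyl-bearing chain. They also leave open whether 1-methyl-1-(methylsulfonyl)ethyl would give a step of similar size alongside the six-membered ring of compound 2, since only the ring system of compound 1 carries it here.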